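The source may report more compounds than this note shows. Statements on the series, on what has been measured and on what is new or still open speak of the compounds shown alone.

In a functional assay on A549 cells (Homo sapiens) for antiproliferative activity, read by MTT assay, with a stated time of 72 h (on this read-out higher numbers stand for weaker inhibition and lower numbers for stronger inhibition), compound 1 `C#Cc1cccc(Nc2ncnc3cc(OC)c(OCCCN4CCNCCNCCNCC4)cc23)c1` gives 28600 nM, and compound 2 `COc1cc2ncnc(Nc3ccc(OCc4cccc(F)c4)c(Cl)c3)c2cc1OCCCN1CCNCCNCCNCC1` gives a lower number, 3400 nM. Compound 3 `C#Cc1cccc(Nc2ncnc3cc(OC)c(OCCCN4CCNCCNCC4)cc23)c1` gives > 50000 nM, which is a limit of the assay and not a number. Its place on the scale is therefore not fixed, and it is the only such case here: the limit of > 50000 nM in this assay, at which 1 of the 3 values shown sits.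

Compound 4 `COc1cc2ncnc(Nc3cccc(C(F)(F)F)c3)c2cc1OCCCN1CCNCCNCC1` differs from compound 3 on one group only: trifluoromethyl in place of ethynyl on an aromatic carbon. In words, trifluoromethyl stands in place of ethynyl on an aromatic carbon, meta to a large group.

Among the measured compounds shown here, only one measured step links close neighbours, an at least 1.7-fold higher number from compound 1 to compound 3 (0.24 log units; that floor lies within the scatter), and it concerns the ring at the end of the chain, not this group. For the measured compounds named here, no measured step exchanges ethynyl for anything else, so the data give no size for this change. The expectation therefore stays with the starting point, and no shift beyond the scatter is foreseen in this assay. The expected step is an at least 1.1-fold lower number from compound 3 to compound 4 (0.04 log units; that floor lies within the scatter), which would leave the number close to the limit of the assay, and a report of a limit alone is quite possible. Compound 4 is estimated at 45000 nM, with an expected range from 18000 nM to 100000 nM.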

Compound 4, half-maximal inhibitory concentration: 37300 nM
Beside the measured number, compound 4's estimate is 1.2-fold (0.08 log units) above it; the measured number falls inside the stated range.
By their numbers in this assay, from the lowest: compound 2; then compounds 1 and 4 (each within the scatter of the next). At a limit, above all of these: compound 3.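

Compound 3 gives > 50000 nM in this assay, which is a limit of the assay and not a number, so any step from it can be read only as a floor: the limit of > 50000 nM in this assay, at which 1 of the 4 values shown sits.

Among the compounds shown here, the exchange of ethynyl for trifluoromethyl on an aromatic carbon, meta to a large group, is the first measured change at this position, and it gives an at least 1.3-fold lower number from compound 3 to compound 4 (0.12 log units; that floor lies within the scatter), so the data show no shift here that can be told apart from the scatter. What is new is that, with the nine-membered ring at the end of the chain kept, compound 4 gives a real number on the scale, 37300 nM, and so offers a fixed point at this position that compound 3 could not.

On these data alone, how far compound 3 lies past its limit stays open, and with it the true size of this step, which may be larger than its floor. Also open, as far as these compounds go, is whether a nitrile, a methoxy group or an amine at this position would move the number beyond the scatter, and how trifluoromethyl would read with the larger ring at the end of the chain of compound 1.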